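The compounds below may be only part of what the source reports. "The series", "measured", "known", "first", "only" and "open" are said of these compounds alone.

Working notes on the series. Compound 1 `C[Se]c1nc(N)c2ccccc2n1` gives 46500 nM in a functional assay on MCF7 cells (Homo sapiens) for cytotoxicity, read by MTT assay, with a stated time of 72 h; on this read-out higher numbers stand for weaker inhibition of growth and lower numbers for stronger inhibition of growth. Compound 3 `CSc1nc(NCCCc2ccccc2)c2ccccc2n1` gives 77200 nM in this assay; the two values sit close together and neither is set apart. Compound 2 `C[Se]c1nc([Se]C)c2cccnc2n1` has no number in this assay, where the entry for compound 2 reads "not determined" (no result reported), so it gives no anchor of its own, and on the numbers shown it stands nowhere.

Compound 4 `C[Se]c1nc(N)c2cccnc2n1` differs from compound 2 as follows: one nitrogen atom in place of a group of 2 heavy atoms (1 carbon, 1 selenium; no ring), on an aromatic carbon. Compound 4 thereby carries the same amino group that compound 1 carries, on a shared core that compound 2 and compound 4 have in common. Going by the values given here, no measured step covers this change, and no pair of measured compounds differs in one place, so the size of the step cannot be read from the data. On what is measured, growth inhibition in this assay for the whole series is weak and flat, and no step beyond the usual scatter is expected from the change. Compound 4 is therefore expected to give about 50000 nM in this assay, with a range from 15000 nM to 160000 nM, resting on the weak value of compound 1 46500 nM.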

Compound 4, concentration for 50% growth inhibition: 43000 nM
Estimate against measurement, compound 4: 1.2-fold (0.07 log units) above; the measured number falls inside the stated range.
By their numbers in this assay, from the lowest: compounds 4, 1 and 3 (each within the scatter of the next).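

In this assay, going by these compounds alone, compound 4 adds no new step, as compound 2, the compound it is set against, has no number there. No measurement shown offers an explanation of these values. The compounds shown leave open whether any single change on the shared core moves growth inhibition beyond the usual scatter.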